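Fluoro for methoxy: expectation for compound 3

The source may report more compounds than this note shows. Statements on the series, on what has been measured and on what is new or still open speak of the compounds shown alone.

In a functional assay on MCF7 cells (Homo sapiens) for cytotoxicity, read by sulforhodamine B assay, with a stated time of 48 h (on this read-out lower numbers stand for stronger inhibition and higher numbers for weaker inhibition), compound 1 (`COc1cc(/C=C/C(=O)c2ccc(N)c(-c3ccc(F)cc3)c2)cc(Br)c1O`) gives 40500 nM and compound 2 (`COc1cc(/C=C/C(=O)c2ccc(N)c(-c3ccc(F)cc3)c2)ccc1O`) gives 10500 nM. Among the measured compounds shown here, compound 2 therefore holds the lower of the two numbers so far. The next structure is compound 3 (`Nc1ccc(C(=O)/C=C/c2ccc(O)c(F)c2)cc1-c1ccc(F)cc1`), and the change from compound 2 is fluoro in place of methoxy on an aromatic carbon. In words, this is fluoro in place of methoxy on an aromatic carbon, ortho to a hydroxy group and meta to a large group, taking 4-hydroxy-3-methoxyphenyl to 3-fluoro-4-hydroxyphenyl.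

For the measured compounds named here, only one measured step bears on this: a 3.9-fold lower number from compound 1 to compound 2 (0.59 log units; beyond the scatter), with hydrogen in place of bromo on an aromatic carbon. Going by the values given here, that step is modest and leaves the methoxy group in place, so no measurement yet shows what exchanging the methoxy group does. The data give no firm direction, and a shift no larger than that modest step is expected, quite possibly none beyond the scatter. The expected change is a 1.1-fold higher number from compound 2 to compound 3 (0.06 log units; within the scatter). For compound 3 the estimated value is 12000 nM, with an expected range of 5000 nM to 30000 nM.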

Compound 3, half-maximal inhibitory concentration: 18300 nM
The estimate for compound 3 lay 1.5-fold (0.18 log units) below the measured number, within the range that was stated.
By their numbers in this assay, from the lowest: compounds 2 and 3 (each within the scatter of the next); then compound 1.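

In this assay, among the compounds shown here, the exchange of the methoxy group itself reads as a 1.7-fold higher number from compound 2 to compound 3 (0.24 log units; within the scatter), the first measured change of that group. For the compounds shown here, at this position, then, the methoxy group, with 2 heavy atoms and 1 hydrogen-bond acceptor, and fluoro, with 1 heavy atom and 0 hydrogen-bond acceptors, are not told apart by this read-out, so 4-hydroxy-3-methoxyphenyl and 3-fluoro-4-hydroxyphenyl stand level here, whereas the bromo to hydrogen exchange, a 3.9-fold lower number from compound 1 to compound 2 (0.59 log units; beyond the scatter), remains the only step beyond the scatter. No measurement at hand accounts for this result or ties it to any property of either group.

Open, on these data alone, is whether this position tolerates groups of another kind, such as an ethoxy group, an amine or a carboxylic acid, as it tolerates fluoro, since methoxy and fluoro are the only two compared here. Also open, as far as these compounds go, is what exchanging the hydroxy group does, since it stays in place in compound 1, compound 2 and compound 3.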